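Triazole series on prostate carcinoma cells: halogen swap

The compounds below may be only part of what the source reports. "The series", "measured", "known", "first", "only" and "open" are said of these compounds alone.

Measured so far:
Compound 1 `COc1cccc(CSc2nnc([C@@H](C)c3ccc4cc(OC)ccc4c3)n2-c2ccc(Cl)cc2)c1` gives 138000 nM in a functional assay on PC-3 cells (Homo sapiens) for cytotoxicity, read by MTT assay; on this read-out higher numbers stand for weaker inhibition and lower numbers for stronger inhibition.
Compound 2 `COc1ccc2cc([C@H](C)c3nnc(SCc4c(Cl)cccc4Cl)n3-c3ccc(F)cc3)ccc2c1` gives 216000 nM in this assay.
Compound 3 `COc1cccc(CSc2nnc([C@@H](C)c3ccc4cc(OC)ccc4c3)n2-c2ccc(F)cc2)c1` gives 211000 nM in this assay.

All three numbers sit close together. Compound 2 has the highest of the three, yet its gaps to compound 3 and to compound 1 are both within the scatter, so no ordering among them can be claimed. Compound 3 and compound 2 share everything but the group on the sulfur-bound carbon: 2,6-dichlorophenyl in place of 3-methoxyphenyl on a saturated chain carbon bound to a sulfur. That change gives a 1.0-fold lower number from compound 2 to compound 3 (0.01 log units; within the scatter).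

Compound 1 and compound 3 differ only at the halogen: chloro in place of fluoro on an aromatic carbon. The measured step is a 1.5-fold lower number from compound 3 to compound 1 (0.18 log units; within the scatter).

Compound 4 `COc1ccc2cc([C@H](C)c3nnc(SCc4c(Cl)cccc4Cl)n3-c3ccc(Cl)cc3)ccc2c1` is not yet measured in this assay. It stands to compound 2 as compound 1 stands to compound 3: chloro in place of fluoro on an aromatic carbon. The place line reads the same in both cases, so this is the same change. Within the data shown here, the only guide is the one earlier instance, which stayed within the scatter, and the core of compound 2 differs from that of compound 3 only by the sulfur-bound group already described.

For compound 4 the expected step is a 1.4-fold lower number from compound 2 to compound 4 (0.13 log units; within the scatter), about the size seen from compound 3 to compound 1, because that step was a 1.5-fold lower number from compound 3 to compound 1 (0.18 log units; within the scatter). Compound 4 is thus estimated at 160000 nM in this assay, with a plausible range from 75000 nM to 330000 nM.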

Compound 4, half-maximal inhibitory concentration: 34700 nM
Compound 4: the middle estimate sits 4.6-fold (0.66 log units) above what was measured; the whole stated range lies above it.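

In this assay, chloro in place of fluoro on an aromatic carbon gives a 6.2-fold lower number from compound 2 to compound 4 (0.79 log units; beyond the scatter), so this change cannot be carried at a fixed size from the core of compound 3 to the core of compound 2: the same change on two cores in this assay, a 1.5-fold lower number (0.18 log units; within the scatter) from compound 3 to compound 1 and a 6.2-fold lower number (0.79 log units; beyond the scatter) from compound 2 to compound 4, 4.1-fold (0.61 log units) apart, beyond the scatter of two such steps

The sulfur-side change behaves the same way, with 2,6-dichlorophenyl in place of 3-methoxyphenyl giving a 4.0-fold lower number from compound 1 to compound 4 (0.60 log units; beyond the scatter), so the effect of that change also depends on the rest of the molecule: the same change on two cores in this assay, a 1.0-fold lower number (0.01 log units; within the scatter) from compound 2 to compound 3 and a 4.0-fold higher number (0.60 log units; beyond the scatter) from compound 4 to compound 1, 4.1-fold (0.61 log units) apart, beyond the scatter of two such steps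

Within these four compounds, the two changes are therefore not independent, and both steps beyond the scatter end at compound 4, which combines 4-chlorophenyl with 2,6-dichlorophenyl; the result does not show why this pairing stands apart, and it rests on a single set of four compounds, so it does not establish a rule for other cores.

As far as these compounds go, it remains open whether bromo in place of chloro, para to a large group, would keep the lower number seen for compound 4. Also open, from the compounds shown here alone, is how an amine on the aromatic ring of the sulfur-side group, or a longer chain in place of the saturated chain carbon bound to a sulfur, would read on the core of compound 4.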